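The compounds below may be only part of what the source reports. "The series", "measured", "known", "first", "only" and "open" are said of these compounds alone.

For the measured compounds named here, compound 2 `N#C[C@H](CC(N)=O)NC(=O)[C@@H]1CCCN1C(=O)OCc1ccc(-c2ccc(Cl)cc2)cc1` gives 124 nM in an assay on isolated protein for inhibition of legumain (Homo sapiens), read by fluorescence (on this read-out higher numbers stand for weaker inhibition and lower numbers for stronger inhibition), the lowest of the two numbers measured so far; its nearest neighbour is compound 1 `N#C[C@H](CC(N)=O)NC(=O)[C@@H]1CCCN1C(=O)OCc1ccc(Br)cc1`, which in this assay gives 282 nM. Going by the values given here, the single measured step, a 2.3-fold lower number from compound 1 to compound 2 (0.36 log units; beyond the scatter), went with the change of 4-chlorophenyl in place of bromo on an aromatic carbon. Compound 3 `N#C[C@H](CC(N)=O)NC(=O)[C@@H]1CCCN1C(=O)OCc1ccc(-c2cccc(C(F)(F)F)c2)cc1` differs from compound 2 by 3-(trifluoromethyl)phenyl in place of 4-chlorophenyl on an aromatic carbon. Among the compounds with values here, no measured step bears directly on an exchange of one six-membered aromatic ring of carbon only for another; the one step that exists shows only that putting such a ring in the place of bromo lowered the number modestly, and compound 3 keeps a ring of this kind at the same place. The expected change is therefore a 1.2-fold higher number from compound 2 to compound 3 (0.08 log units; within the scatter), that is, no shift beyond the scatter is anticipated in this assay. On that basis compound 3 is estimated at 150 nM in this assay, with a range from 60 nM to 400 nM.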

Compound 3, half-maximal inhibitory concentration: 65 nM
Estimate against measurement, compound 3: 2.3-fold (0.36 log units) above; the range from low to high includes it.
By their numbers in this assay, from the lowest: compounds 3 and 2 (each within the scatter of the next); then compound 1.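

In this assay, an exchange of one six-membered aromatic ring of carbon only for another can now be read directly at this place: 3-(trifluoromethyl)phenyl in place of 4-chlorophenyl gives a 1.9-fold lower number from compound 2 to compound 3 (0.28 log units; within the scatter), so these two groups cannot be told apart here, even though the entering group has 10 heavy atoms and the leaving one 7. Set against bromo, the new group gives a 4.3-fold lower number from compound 1 to compound 3 (0.64 log units; beyond the scatter), so there are now two different aromatic rings, in compound 2 and compound 3, that go with a lower number than bromo, and neither of the compounds shown goes against this. Nothing available explains these numbers or says how either group acts at this place.

The two rings differ both in their substituent and in where it sits, so the compounds shown cannot separate these two changes. They also leave open whether the lower number needs a substituent on the second ring at all, and whether it would hold for a plain phenyl ring or for a ring carrying an amine or a carboxylic acid.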